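A few compounds are considered here, and "the series" means these few. Any claim that something is new, unique, unknown or untested is made for them only; others in the source may bear on it.

Of the compounds shown here, two built on one shared core have been tested so far. In a functional assay on MCF7 cells (Homo sapiens) for cytotoxicity, read by MTT assay, with a stated time of 48 h (a lower number here means a stronger inhibitor of growth, a higher number a weaker inhibitor of growth), compound 1 `C=CCn1c(C(F)(F)F)nc2cc(Cl)c(Cl)cc21` gives 87000 nM and compound 2 `O=[N+]([O-])c1cccc(Cn2c(C(F)(F)F)nc3cc(Cl)c(Cl)cc32)c1` gives 60000 nM, two values that lie within the usual scatter of each other. Compound 2 therefore stands level with compound 1, and the data cannot rank one above the other, even though the group attached to the shared core differs between them.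

Compound 3 `Nc1cccc(Cn2c(C(F)(F)F)nc3cc(Cl)c(Cl)cc32)c1` keeps all of compound 2 except for one group, with amino in place of nitro on an aromatic carbon. Within the data shown here, no pair of tested compounds shows what this swap does in this assay, so nothing measured points to a direction. Starting from compound 2 at 60000 nM, the expectation is therefore no step beyond the scatter. The expected change is small, and the estimate is a 1.2-fold lower number from compound 2 to compound 3 (0.08 log units; within the scatter). With so little to go on, the range has to stay wide. For compound 3 the estimated value is 50000 nM, with an expected range from 15000 nM to 120000 nM.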

Compound 3, concentration for 50% growth inhibition: 77500 nM
Compound 3: middle estimate off by 1.6-fold (0.19 log units), on the low side, and the stated range covers the measured number.
By their numbers in this assay, from the lowest: compounds 2, 3 and 1 (each within the scatter of the next).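

In this assay, among these compounds, the first reading of amino in place of nitro on this aromatic carbon, meta to a large group, is a step within the scatter (a 1.3-fold higher number from compound 2 to compound 3 (0.11 log units; within the scatter)), so at this position the swap does not separate the two compounds, even though nitro has 3 heavy atoms and no hydrogen-bond donor while amino has 1 heavy atom and 1 hydrogen-bond donor. A larger change at the saturated chain carbon bound to an aromatic nitrogen, 3-aminophenyl in place of vinyl, also stays within the scatter (a 1.1-fold lower number from compound 1 to compound 3 (0.05 log units; within the scatter)), which means that none of the three compounds can be ranked above another. No measurement shown here bears on the reason for this result.

Going by these compounds, it remains open whether a carboxylic acid or a nitrile on this aromatic carbon would produce a step beyond the scatter. Also open, on these data alone, is what a longer chain in place of the allyl group, or a methyl group in place of the trifluoromethyl group on the shared core, would do in this assay.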